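Carboxy in Place of Chloro on the Sulfonamide Phenol

The source may report more compounds than this note shows. Statements on the series, on what has been measured and on what is new or still open speak of the compounds shown alone.

Measured so far:
compound 1 `O=S(=O)(Nc1ccc(O)cc1)c1ccc(-c2ccccc2)cc1` — 2500 nM; 5000 nM (2 entries)
compound 2 `O=S(=O)(Nc1ccc(O)c(F)c1)c1ccc(-c2ccccc2)cc1` — > 20000 nM
compound 3 `O=S(=O)(Nc1ccc(O)c(Cl)c1)c1ccc(-c2ccccc2)cc1` — > 20000 nM

Of the compounds shown here, three have been measured in an assay on HepG2 cells for inhibition of cytochrome b-c1 complex subunit 7 (Homo sapiens), read by Western blot, with a stated time of 4 h; a lower number here means a stronger inhibitor, a higher number a weaker inhibitor. Among the compounds with values here, compound 1 is the only one with a number, and its repeated entries are recorded as the several entries of compound 1 in this assay, 2500 nM; 5000 nM (2 entries). Compound 2 sits at a limit of the assay, > 20000 nM, not at a number. Compound 3 likewise sits at a limit of the assay, > 20000 nM. The step that the two limits leave unreadable from compound 2 to compound 3 therefore cannot be read, since both ends are limits; this is the limit of > 20000 nM in this assay, at which 2 of the 3 values shown sit.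

Compound 4 `O=C(O)c1cc(NS(=O)(=O)c2ccc(-c3ccccc3)cc2)ccc1O` differs from compound 3 by carboxy in place of chloro on an aromatic carbon. Within the data shown here, no measured step touches a carboxy group, and the only step that changes the same position, a step that the two limits leave unreadable from compound 2 to compound 3, has no readable size. What can be said is that both substituted analogues, compound 2 and compound 3, stand at the limit, while the unsubstituted compound 1 stands at (the several entries of compound 1 in this assay, 2500 nM; 5000 nM (2 entries)).

With so little to lean on, the expectation for the step of an at least 1.3-fold lower number from compound 3 to compound 4 (0.12 log units; that floor lies within the scatter) is that it stays unreadable against the scatter. Compound 4 is thus expected to give about 15000 nM, within a wide range from 3000 nM to 60000 nM, with a fair chance that only a limit is reported.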

Compound 4, half-maximal inhibitory concentration: > 20000 nM
Compound 4: a limit, no number; the forecaster's own chance of this, stated with the estimate: 55%; middle value at least 1.3-fold (0.12 log units) away from the limit.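

In this assay compound 4 gives > 20000 nM, a limit and not a number, so its steps from compound 2 and compound 3 cannot be read, all three being limits. The compounds shown leave open how compound 2, compound 3 and compound 4 rank among themselves.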